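A few compounds are considered here, and "the series" means these few. Any claim that something is new, unique, unknown or untested is made for them only; others in the source may bear on it.

Among the compounds with values here, compound 2 `CN(C)CCNc1nc(-c2ccc(NC(=O)Nc3ccc(Cl)cc3)cc2)nc2c(Cl)c(Cl)sc12` stands lowest of the two numbers so far in a functional assay on NCI-H460 cells (Homo sapiens) for cytotoxicity, read by MTT assay, with a stated time of 72 h (a higher number here means a weaker inhibitor, a lower number a stronger inhibitor), where compound 2 gives 300 nM. Compound 1 `CN(C)CCCNc1nc(-c2ccc(NC(=O)Nc3ccc(Cl)cc3Cl)cc2)nc2c(Cl)c(Cl)sc12` differs from compound 2 in several places; in this assay compound 1 gives 980 nM, and the two values show a gap beyond the scatter. Compound 3 `CN(C)CCNc1nc(-c2ccc(NC(=O)Nc3ccc(Cl)cc3Cl)cc2)nc2c(Cl)c(Cl)sc12` carries the change (chloro in place of hydrogen on an aromatic carbon), chloro in place of hydrogen on an aromatic carbon. Within the data shown here, no measured pair isolates this change, so the number of compound 2 is the anchor. A modest weakening is expected for the step of a 1.7-fold higher number from compound 2 to compound 3 (0.22 log units; within the scatter). Compound 3 is therefore expected near 500 nM, within 200 nM to 1300 nM.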

Compound 3, half-maximal inhibitory concentration: 1520 nM
Estimate against measurement, compound 3: 3.0-fold (0.48 log units) below, and the stated range ends below it.
By their numbers in this assay, from the lowest: compound 2; then compounds 1 and 3 (each within the scatter of the next).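

In this assay, within the data shown here, chloro in place of hydrogen on this aromatic carbon, ortho to a large group, gives a 5.1-fold higher number from compound 2 to compound 3 (0.70 log units; beyond the scatter) and so brings a clear loss of activity in the first comparison that isolates one place. With the 2,4-dichlorophenyl group kept, dimethylamino in place of (dimethylamino)methyl on the chain gives a 1.6-fold higher number from compound 1 to compound 3 (0.19 log units; within the scatter) and so shows no readable difference. Nothing measured here accounts for the loss. As far as these compounds go, whether fluoro or methyl on that carbon would give a similar step stays open, as does whether the chain change would read the same with the 4-chlorophenyl group.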